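Working notes: the step from compound 1 to compound 3

The compounds below may be only part of what the source reports. "The series", "measured", "known", "first", "only" and "open" are said of these compounds alone.

Compound 1 `NNC(=O)CCc1ccncc1-c1ccc2ccccc2c1`: > 10000 nM
Compound 2 `Cn1ncc2cc(-c3cnccc3/C=C/C(=O)O)ccc21`: > 10000 nM

Both entries come from a functional assay on MCF7 cells (Homo sapiens) for inhibition, read by sulforhodamine B assay, with a stated time of 72 h (on this read-out lower numbers stand for stronger inhibition of growth and higher numbers for weaker inhibition of growth), and each is a limit of the assay and not a number. Compound 1 therefore has no exact position in the series, and the only statement available is the limit of > 10000 nM in this assay, at which 2 of the 2 values shown sit.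

Compound 3 `CN(C)C(=O)/C=C/c1ccncc1-c1ccc2ccccc2c1` has not yet been measured in this assay. It carries 2-(dimethylcarbamoyl)ethenyl in place of 2-(aminocarbamoyl)ethyl on an aromatic carbon of a six-membered aromatic ring with 1 nitrogen, ortho to a large group and opposite the ring nitrogen: 2-(dimethylcarbamoyl)ethenyl in place of 2-(aminocarbamoyl)ethyl on an aromatic carbon.

Going by the values given here, the series offers no step between measured compounds, so the size of this change cannot be read from the data. Compound 1 gives > 10000 nM, which is a limit, and that leaves only a weak basis for any expectation. In this assay, no step beyond the scatter is expected in either direction. The expected step of a number no higher from compound 1 to compound 3 (the limit leaves the size open) is an estimate only. For compound 3 the estimated value is 10000 nM, with an expected range of 3000 nM to 30000 nM.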

Compound 3, concentration for 50% growth inhibition: 8190 nM
Estimate against measurement, compound 3: 1.2-fold (0.09 log units) above, and the stated range covers the measured number.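

In this assay compound 3 gives 8190 nM, a number and not a limit, so this position on the shared core now has one exact reading. Compound 1 gives > 10000 nM, which is a limit of the assay. Placing 2-(dimethylcarbamoyl)ethenyl in place of 2-(aminocarbamoyl)ethyl on this aromatic carbon, opposite the ring nitrogen, gives an at least 1.2-fold lower number from compound 1 to compound 3 (0.08 log units; that floor lies within the scatter), so the true size of the step stays open, and compound 3 is the only compound shown with an exact value: the limit of > 10000 nM in this assay, at which 2 of the 3 values shown sit.

The change alters the link and the end of the chain together, so the compounds shown do not separate the ethenyl link from the dimethylcarbamoyl end; 2-(dimethylcarbamoyl)ethyl or 2-(aminocarbamoyl)ethenyl on the same core would make that separation. Also open, on these data alone, is whether a longer chain, or a chain ending in an amine, at this position would give a number lower than that of compound 3 by more than the scatter.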